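A few compounds are considered here, and "the series" means these few. Any claim that something is new, unique, unknown or untested is made for them only; others in the source may bear on it.

Series notes. Compound 3 `CN(C)CCCCOC(=O)Nc1ccc(Cn2nc(-c3cccc(F)c3)c3ccccc3c2=O)cc1` gives 37400 nM in an ADME assay on Huh-7 cells (Homo sapiens) for cytotoxicity, read by MTT assay, with a stated time of 48 h; on this read-out lower numbers stand for higher toxicity in this test and higher numbers for lower toxicity in this test. Compound 1 `CN(C)CCCCOC(=O)Nc1ccc(Cn2nc(-c3cncnc3)c3ccccc3c2=O)cc1` gives 65300 nM in this assay, and compound 2 `CN(C)CCCCOC(=O)Nc1ccc(Cn2nc(-c3ccccc3)c3ccccc3c2=O)cc1` gives 16000 nM. On these numbers compound 3 stands second highest: its gap to compound 1, a 1.7-fold lower number from compound 1 to compound 3 (0.24 log units; within the scatter), lies within the scatter, while the gap a 2.3-fold higher number from compound 2 to compound 3 (0.37 log units; beyond the scatter) lies beyond it. The remaining step, a 4.1-fold lower number from compound 1 to compound 2 (0.61 log units; beyond the scatter), is the largest of the set.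

Compound 4 `COc1cccc(-c2nn(Cc3ccc(NC(=O)OCCCCN(C)C)cc3)c(=O)c3ccccc23)c1` has not yet been measured in this assay. It differs from compound 3 by methoxy in place of fluoro on an aromatic carbon. Among the compounds with values here, the one measured step at the same aromatic carbon, a 2.3-fold higher number from compound 2 to compound 3 (0.37 log units; beyond the scatter), was modest, and no measured step introduces a methoxy, so nothing here fixes the direction of the change. The expectation for this assay is therefore a step of about a 1.1-fold lower number from compound 3 to compound 4 (0.03 log units; within the scatter), which would leave the result within the scatter of compound 3. Compound 4 is estimated at 35000 nM, in a range from 15000 nM to 80000 nM.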

Compound 4, half-maximal cytotoxic concentration: 17600 nM
Compound 4: middle estimate off by 2.0-fold (0.30 log units), on the high side, within the range that was stated.
By their numbers in this assay, from the lowest: compounds 2 and 4 (each within the scatter of the next); then compounds 3 and 1 (each within the scatter of the next).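

In this assay the change from fluoro to methoxy on this aromatic carbon is not neutral (a 2.1-fold lower number from compound 3 to compound 4 (0.33 log units; beyond the scatter)), so a substituent here does not by itself carry the number of compound 3. Against the unsubstituted phenyl, methoxy makes no step beyond the scatter (a 1.1-fold higher number from compound 2 to compound 4 (0.04 log units; within the scatter)), so of the two groups at this carbon only fluoro separates from hydrogen, and 3-methoxyphenyl stays clearly apart from pyrimidin-5-yl (a 3.7-fold lower number from compound 1 to compound 4 (0.57 log units; beyond the scatter)), whereas 3-fluorophenyl does not. No measured evidence accounts for this difference between fluoro and methoxy.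

The compounds shown leave open whether the step seen with fluoro extends to other groups on this carbon, such as chloro, hydroxy or an amine. They also leave open whether fluoro or methoxy would act alike on the other carbons of this ring.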